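The source may report more compounds than this note shows. Statements on the series, on what has been measured and on what is new or still open speak of the compounds shown alone.

Measured so far:
compound 1 `OCCCNc1nc(-c2ccccc2)nc2c1nnn2Cc1ccccc1` — 21400000 nM
compound 2 `CC(O)CNc1nc(-c2ccccc2)nc2c1nnn2Cc1ccccc1Cl` — 32000000 nM
compound 3 `CC(O)CNc1nc(-c2ccccc2)nc2c1nnn2Cc1ccccc1F` — 4800000 nM

In an assay on isolated protein for binding affinity to adenosine receptor A1 (Bos taurus) (a higher number here means a weaker inhibitor, a lower number a stronger inhibitor), compound 2 stands highest of the three numbers; compound 1 sits within the scatter of it, and compound 3 lies furthest, with a 6.7-fold lower number from compound 2 to compound 3 (0.82 log units; beyond the scatter). Compound 4 `Clc1ccccc1Cn1nnc2c(NC3CCCCC3)nc(-c3ccccc3)nc21` differs from compound 2 by cyclohexyl in place of 2-hydroxypropyl on a nitrogen on an aromatic ring. Among the compounds with values here, the single measured step, fluoro in place of chloro on an aromatic carbon, leaves the group on the nitrogen on the aromatic ring untouched, so no measured step bears on this change. With nothing to rest on, no step beyond the scatter is expected, and the range is kept wide. Compound 4 is estimated at 15000000 nM, with a range from 1500000 nM to 100000000 nM. This estimate amounts to an expected step of a 2.1-fold lower number from compound 2 to compound 4 (0.33 log units; beyond the scatter).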

Compound 4, inhibition constant: 34000000 nM
Compound 4: the middle estimate sits 2.3-fold (0.36 log units) below what was measured; the measured number falls inside the stated range.
By their numbers in this assay, from the lowest: compound 3; then compounds 1, 2 and 4 (each within the scatter of the next).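

In this assay, within the data shown here, cyclohexyl in place of 2-hydroxypropyl gives the first reading at this nitrogen: a 1.1-fold higher number from compound 2 to compound 4 (0.03 log units; within the scatter). With the chloro group held constant, replacing the open chain, with its hydrogen-bond donor and acceptor, by a carbon-only six-membered ring does not separate the two numbers. No measured evidence accounts for this result.

On these data alone, whether cyclohexyl behaves the same with fluoro in place of chloro stays open, as compound 3 carries 2-hydroxypropyl. As far as these compounds go, how a longer carbon chain, or a cyclohexyl ring bearing an amine or a carboxylic acid, would read also remains open.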